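Swapping a Chloro for a Methyl on the Phenoxy Ring

A few compounds are considered here, and "the series" means these few. Any claim that something is new, unique, unknown or untested is made for them only; others in the source may bear on it.

Of the compounds shown here, two built on one shared core have been tested in a functional assay on HCT-116 cells (Homo sapiens) for antiproliferative activity, read by MTT assay, with a stated time of 72 h; on this read-out lower numbers stand for stronger inhibition and higher numbers for weaker inhibition. Compound 1 `Cc1nn(C)c(Oc2ccc(F)cc2)c1/C=N\OCc1c(Cl)c(-c2ccc(F)cc2)nn1C` gives 8020 nM. Compound 2 `Cc1nn(C)c(Oc2ccc(Cl)cc2)c1/C=N\OCc1c(Cl)c(-c2ccc(F)cc2)nn1C` carries a chloro in place of the fluoro of compound 1. In this assay compound 2 gives 6030 nM. The step of a 1.3-fold lower number from compound 1 to compound 2 (0.12 log units; within the scatter) lies within the scatter, so compound 2 stands within the scatter of compound 1 and nothing sets the two apart.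

Compound 3 `Cc1ccc(Oc2c(/C=N\OCc3c(Cl)c(-c4ccc(F)cc4)nn3C)c(C)nn2C)cc1` has not yet been measured. It differs from compound 2 by methyl in place of chloro on an aromatic carbon. Among the measured compounds shown here, the only step seen so far, a 1.3-fold lower number from compound 1 to compound 2 (0.12 log units; within the scatter), altered this same place and stayed within the scatter, so a further swap at the same place is expected to shift the number little, if at all, in this assay. The estimate for compound 3 is 6500 nM, with a range from 3000 nM to 14000 nM. This means an expected step of a 1.1-fold higher number from compound 2 to compound 3 (0.03 log units; within the scatter).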

Compound 3, half-maximal inhibitory concentration: 2910 nM
Compound 3: the middle estimate sits 2.2-fold (0.35 log units) above what was measured; measured number outside the range, below it.
By their numbers in this assay, from the lowest: compound 3; then compounds 2 and 1 (each within the scatter of the next).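

The place on the phenoxy ring is not silent in this assay: the swap between fluoro and chloro set nothing apart, yet methyl in place of chloro gives a 2.1-fold lower number from compound 2 to compound 3 (0.32 log units; beyond the scatter), and methyl in place of fluoro gives a 2.8-fold lower number from compound 1 to compound 3 (0.44 log units; beyond the scatter). The number can therefore move at this place, though only modestly, and among the three groups shown methyl gives the lowest number, while fluoro and chloro stay within the scatter of each other. No measurement at hand says why methyl stands apart from fluoro and chloro.

Still open, on these data alone, is whether the lower number belongs to methyl alone or also extends to a longer chain such as ethyl, to methoxy or to an amine at this place. As far as these compounds go, whether the same swap would act alike on a different core also remains unknown.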